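The source may report more compounds than this note shows. Statements on the series, on what has been measured and on what is new or still open speak of the compounds shown alone.

Measured compounds in a functional assay on thoracic aorta (Rattus norvegicus, strain Wistar), with a stated time of 15 min; a higher number here means that more compound is needed for the effect, a lower number that less compound is needed:
Compound 1 `COc1ccc(Br)cc1C(C)NC(=O)NS(=O)(=O)c1ccccc1`: compound 1 gives only a limit of the assay, > 300000 nM.
Compound 2 `COc1ccc(Br)cc1C(C)NC(=O)N(C)S(=O)(=O)c1ccc(Cl)cc1`: compound 2 gives 19100 nM.
Compound 3 `CC(C)Oc1ccc(Br)cc1C(C)NC(=O)NS(=O)(=O)c1ccccc1`: compound 3 gives 143000 nM.

The difference between the core of compound 1 and the core of compound 2 is not broken down here. Compound 3 differs from compound 1 by isopropyl in place of methyl on an oxygen on an aromatic ring. That change gave an at least 2.0-fold lower number from compound 1 to compound 3 (0.32 log units; beyond the scatter); because compound 1 sits at the limit of > 300000 nM in this assay, at which 1 of the 3 values shown sits, the true size of this step is open upwards. Among the two actual numbers compound 2 stands lowest, with compound 3 nearest.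

Compound 4 `CC(C)Oc1ccc(Br)cc1C(C)NC(=O)N(C)S(=O)(=O)c1ccc(Cl)cc1` is not yet measured. It differs from compound 2 by isopropyl in place of methyl on an oxygen on an aromatic ring, the same change seen between compound 1 and compound 3. Carrying the measured step over, the expected step in this assay is a 2.4-fold lower number from compound 2 to compound 4 (0.38 log units; beyond the scatter). For compound 4 the estimate in this assay is 8000 nM, expected to fall between 3000 nM and 20000 nM. This rests on compound 2 at 19100 nM and on the step of an at least 2.0-fold lower number from compound 1 to compound 3 (0.32 log units; beyond the scatter).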

Compound 4, half-maximal effective concentration: 43200 nM
Compound 4: middle estimate off by 5.4-fold (0.73 log units), on the low side; measured number outside the range, above it.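

In this assay, isopropyl in place of methyl on an oxygen on an aromatic ring gives a 2.3-fold higher number from compound 2 to compound 4 (0.35 log units; beyond the scatter). Set beside the earlier step, the same change runs in opposite directions on the two cores, so in this series it does not carry from one core to the other as a fixed step: the same change on two cores in this assay, an at least 2.0-fold lower number (0.32 log units; beyond the scatter) from compound 1 to compound 3 and a 2.3-fold higher number (0.35 log units; beyond the scatter) from compound 2 to compound 4, at least 4.7-fold (0.67 log units) apart, beyond the scatter of two such steps. From the compounds shown here alone, this does not show which part of the difference between the two cores sets the direction, and the size of the earlier step stays open, with compound 1 standing at a limit of the assay: the limit of > 300000 nM in this assay, at which 1 of the 4 values shown sits.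

With only one pair on each core, the compounds shown leave open which direction the change takes on any further core. They also leave open how an ethyl, a longer chain or a free hydroxyl in place of the methoxy or isopropoxy group would read in this assay on either core.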